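Phenyl in place of (pyridin-4-yl)carbonyl: compound 3 to compound 4

The source may hold more compounds than are shown below. What is called first, only, known or untested is meant among the compounds shown, and "the series" means these compounds.

In an ADME assay on Vero cells (Chlorocebus sabaeus) for cytotoxicity, read by MTT assay, with a stated time of 72 h (a higher number here means that more compound is tolerated, a lower number that less compound is tolerated), compound 1 (`COc1c(N2CCN(CCC#N)C(C)C2)c(F)cc2c(=O)c(C(=O)O)cn(C3CC3)c12`) gives 500 ug/mL and compound 3 (`COc1c(N2CCN(C/C(C)=N/NC(=O)c3ccncc3)C(C)C2)c(F)cc2c(=O)c(C(=O)O)cn(C3CC3)c12`) gives 250 ug/mL with the two numbers lying within the scatter of each other. For compound 2 (`CCOC(=O)CCN1CCN(c2c(F)cc3c(=O)c(C(=O)O)cn(C4CC4)c3c2OC)CC1C`) the entry reads "not determined" (no result reported) and no number exists. Among the compounds with values here, compound 3 therefore stands level with the only other compound that has a number.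

The change leading to compound 4 (`COc1c(N2CCN(C/C(C)=N/Nc3ccccc3)C(C)C2)c(F)cc2c(=O)c(C(=O)O)cn(C3CC3)c12`) is phenyl in place of (pyridin-4-yl)carbonyl on an amine nitrogen and in words it is phenyl in place of (pyridin-4-yl)carbonyl on an amine nitrogen. Cut one bond further out, it reads ((pyridin-4-yl)carbonyl)amino to anilino.

Within the data shown here, only one measured step is available, and it bears on this change only indirectly. That step is a 2.0-fold lower number from compound 1 to compound 3 (0.30 log units; within the scatter) and it stays within the scatter even though it puts a larger group carrying the (pyridin-4-yl)carbonyl in place of a much smaller one. Among the measured compounds shown here, no measured step removes this group or introduces phenyl, so the data hold no direct test of the swap. A shift beyond the scatter is not expected, and the estimated change is a 1.3-fold lower number from compound 3 to compound 4 (0.10 log units; within the scatter) in this reading. Compound 4 is estimated at 200 ug/mL with an expected range from 70 ug/mL to 500 ug/mL when it is measured.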

Compound 4, half-maximal cytotoxic concentration: 11.1 ug/mL
Compound 4: middle estimate off by 18-fold (1.26 log units), on the high side; the whole stated range lies above it.
By their numbers in this assay, from the lowest: compound 4; then compounds 3 and 1 (each within the scatter of the next).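

In this assay, within the data shown here, the group on this amine nitrogen proves to matter far more than the earlier compounds showed: phenyl in place of (pyridin-4-yl)carbonyl gives a 23-fold lower number from compound 3 to compound 4 (1.35 log units; beyond the scatter), whereas the only earlier step, a 2.0-fold lower number from compound 1 to compound 3 (0.30 log units; within the scatter), gave no sign of such sensitivity. Group size alone does not order these three compounds, since the group in compound 3 is the larger one and stays within the scatter of compound 1, while the smaller group in compound 4 gives a 45-fold lower number from compound 1 to compound 4 (1.65 log units; beyond the scatter), both measured against the same small nitrile-bearing chain. No measurement shown here accounts for this drop.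

The swap removes the carbonyl and the pyridine ring nitrogen together, so the compounds shown do not tell which of the two, if either, carries the change. A benzoyl group or a pyridin-4-yl group on the same amine nitrogen would separate the two, and nothing shown says how a phenyl ring carrying a substituent such as a methoxy group or a chlorine atom would behave here.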